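The source may hold more compounds than are shown below. What is called first, only, known or untested is meant among the compounds shown, and "the series" means these compounds.

Compound 1 `CCCCCCCCn1cc(COC[C@@H]2OC[C@H](N)[C@@H]2O)nn1`: 70400 nM
Compound 2 `CCCCCCCCCCCCCCn1cc(COC[C@@H]2OC[C@H](N)[C@@H]2O)nn1`: 8210 nM
Compound 3 `CCCCCCCCn1cc(COC[C@@H]2OC[C@H](N)[C@H]2O)nn1`: > 128000 nM

All three values come from a functional assay on MGC-803 cells (Homo sapiens) for antiproliferative activity, read by MTT assay, with a stated time of 48 h; on this read-out lower numbers stand for stronger inhibition and higher numbers for weaker inhibition. Compound 3 gives only a limit of the assay, > 128000 nM, and not a number. The measured comparison with its mirror-drawn partner is an at least 1.8-fold higher number from compound 1 to compound 3 (0.25 log units; that floor lies within the scatter), and the fact that compounds 1 and 3 differ only in the configuration as drawn is all that separates them.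

Compound 4 `CCCCCCCCCCCCn1cc(COC[C@@H]2OC[C@H](N)[C@H]2O)nn1` differs from compound 3 as follows: butyl in place of hydrogen on a saturated chain carbon, eight bonds along the chain from an aromatic nitrogen. The closest guide is an 8.6-fold lower number from compound 1 to compound 2 (0.93 log units; beyond the scatter), where hexyl was added at this same place, though in the other configuration. Butyl is the shorter addition, so a smaller drop in the same direction is expected. The expected size is an at least 3.2-fold lower number from compound 3 to compound 4 (0.50 log units; beyond the scatter). For compound 4 the estimate is 40000 nM, with an expected range of 12000 nM to 128000 nM.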

Compound 4, half-maximal inhibitory concentration: 115000 nM
Beside the measured number, compound 4's estimate is 2.9-fold (0.46 log units) below it, and the stated range covers the measured number.
By their numbers in this assay, from the lowest: compound 2; then compounds 1 and 4 (each within the scatter of the next). At a limit, above all of these: compound 3.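

In this assay, butyl at this place gives an at least 1.1-fold lower number from compound 3 to compound 4 (0.04 log units; that floor lies within the scatter), so this configuration now has a measured number, but no drop beyond the scatter can be claimed. Compound 3 stands only at a limit, so this step has a floor and no exact size, and that floor rests on one value: the limit of > 128000 nM in this assay, at which 1 of the 4 values shown sits.

Hexyl gave an 8.6-fold lower number from compound 1 to compound 2 (0.93 log units; beyond the scatter) in the other configuration, and whether a longer chain such as octyl, placed here in this configuration, would bring a comparable drop stays open. So does whether an amine at this place would change the number.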